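From acetamido to hydroxy on the cyclohexyl ring

This account rests on a few compounds, and the source may have more. Where it says the series, first, only, none or still open, it means among the compounds named here.

In an ADME assay on cells (Hepatocyte, Mus musculus) for metabolic stability, with a stated time of 30 min (a higher number here means that more of the compound is left, a lower number that less of the compound is left), compound 3 `CC(=O)NC1CCC(CN2CCN(c3cc(=O)c4cc(C(F)(F)F)cc([N+](=O)[O-])c4s3)CC2)CC1` gives 94.9%, within the scatter of compound 1 `O=c1cc(N2CCN(CC3CCC(NS(=O)(=O)c4ccccc4)CC3)CC2)sc2c([N+](=O)[O-])cc(C(F)(F)F)cc12` at 95.3%. Compound 2 `O=C(OC1CCC(CN2CCN(c3cc(=O)c4cc(C(F)(F)F)cc([N+](=O)[O-])c4s3)CC2)CC1)C1CCCCC1` lies far from both at 1.2%.

The next change leads to compound 4 `O=c1cc(N2CCN(CC3CCC(O)CC3)CC2)sc2c([N+](=O)[O-])cc(C(F)(F)F)cc12`, with hydroxy in place of acetamido on a saturated ring carbon.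

For the measured compounds named here, three measured steps bear on this change. Acetyl in place of phenylsulfonyl on an amine nitrogen gives a number 0.4 percentage points lower from compound 1 to compound 3 (within the scatter), so that exchange leaves the read-out within the scatter. Acetamido in place of (cyclohexylcarbonyl)oxy gives a number 93.7 percentage points higher from compound 2 to compound 3 (beyond the scatter), and the matching step a number 94.1 percentage points lower from compound 1 to compound 2 (beyond the scatter) is just as large. Going by the values given here, compound 2 is the only measured compound with oxygen on that ring carbon, while compounds 1 and 3 carry nitrogen there. Among the compounds with values here, compound 4 shares the oxygen but lacks the cyclohexylcarbonyl part, and no measured compound carries a free hydroxy. The data therefore cannot separate these two features, and a fall as deep as that of compound 2 remains possible but is not the likeliest result.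

A moderate fall is expected, and the estimated step is a number 14.9 percentage points lower from compound 3 to compound 4 (beyond the scatter). For compound 4 the estimated value is 80%, with an expected range of 50% to 97%.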

Compound 4, percent of the compound remaining: 51.2%
The estimate for compound 4 lay 28.8 percentage points above the measured number, within the range that was stated.
By their numbers in this assay, from the lowest: compound 2; then compound 4; then compounds 3 and 1 (each within the scatter of the next).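

In this assay, the free hydroxy separates the two features that compound 2 combined, the oxygen on the ring carbon and the cyclohexylcarbonyl part: a number 50 percentage points higher from compound 2 to compound 4 (beyond the scatter), so oxygen on this carbon does not by itself bring the read-out down to the level of compound 2. Oxygen in this place is nevertheless not equivalent to the nitrogen-linked groups, with a number 43.7 percentage points lower from compound 3 to compound 4 (beyond the scatter) and a number 44.1 percentage points lower from compound 1 to compound 4 (beyond the scatter), even though the acetamido and (phenylsulfonyl)amino compounds themselves lie within the scatter of each other. No measured evidence on the origin of these steps is at hand.

On these data alone, it remains open whether the high read-outs depend on the nitrogen link itself or on the acetyl and phenylsulfonyl parts carried on it, and a free amine or a methyl ether on the same ring carbon would address that question. As far as these compounds go, it also remains open whether a small ester such as an acetate would fall as far as compound 2, or whether the cyclohexyl part of its ester matters for that result.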